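A few compounds are considered here, and "the series" means these few. Any claim that something is new, unique, unknown or untested is made for them only; others in the source may bear on it.

Compound 1 `O=C(Nc1nc2ccc(N/C(S)=N/C3=CC4OCCOC4C=C3)cc2s1)C1CCCCC1`: 1.6 ug/mL
Compound 2 `CC(C)OC(=O)Nc1nc2ccc(NC(=O)c3c(Cl)cccc3Cl)cc2s1`: 0.0026 ug/mL

In a functional assay on WI-38 VA13 cells (Homo sapiens) for cytotoxicity (a higher number here means that more compound is needed for the effect, a lower number that less compound is needed), compound 2 gives 0.0026 ug/mL, the lower of the two numbers shown, while compound 1 gives 1.6 ug/mL, far above it and beyond the scatter. Compound 3 `COc1ccccc1Nc1nc2ccc(NC(=O)c3c(Cl)cccc3Cl)cc2s1` differs from compound 2 by 2-methoxyphenyl in place of isopropoxycarbonyl on a nitrogen on an aromatic ring. Within the data shown here, no measured pair shows this change, so its effect is open. The expectation is a moderate rise in the number, beyond the scatter, the estimated step being a 7.7-fold higher number from compound 2 to compound 3 (0.89 log units; beyond the scatter). Compound 3 is therefore expected to give about 0.02 ug/mL, within 0.002 ug/mL to 0.3 ug/mL.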

Compound 3, half-maximal effective concentration: > 7.2 ug/mL
Compound 3: a limit, no number (the forecaster's own chance of this, stated with the estimate: 5%); middle value at least 360-fold (2.55 log units) away from the limit.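

In this assay the exchange of isopropoxycarbonyl for 2-methoxyphenyl gives an at least 2700-fold higher number from compound 2 to compound 3 (3.44 log units; beyond the scatter) on this nitrogen on an aromatic ring. Among these compounds, this is the first change read at a single place, and it shows that the number is highly sensitive to the group held there. The reading for compound 3 is a limit and not a number: the limit of > 7.2 ug/mL in this assay, at which 1 of the 3 values shown sits.

On these data alone, with a single change at this position, it stays open whether the step follows from the loss of isopropoxycarbonyl or from the entry of 2-methoxyphenyl. An ethoxycarbonyl group or an unsubstituted phenyl on the same nitrogen would separate the two.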